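A few compounds are considered here, and "the series" means these few. Any claim that something is new, unique, unknown or untested is made for them only; others in the source may bear on it.

Compound 1 `CCCCCCCCCC(=O)OCC1CN(C(=O)c2cc(OC)c(OC)c(OC)c2)CCN1C(=O)c1cc(OC)c(OC)c(OC)c1` gives the lowest number of the three measured compounds in a functional assay (Oryctolagus cuniculus) for inhibition of platelet-activating factor receptor (Cavia porcellus) (on this read-out lower numbers stand for stronger inhibition and higher numbers for weaker inhibition), namely 2820 nM. Compound 3 `COc1cc(N2CCN(c3cc(OC)c(OC)c(OC)c3)CC2)cc(OC)c1OC` gives 12500 nM in this assay, and compound 2 `CCCCCCCCCCCCCCCCCC(=O)OCC1CN(C(=O)c2cc(OC)c(OC)c(OC)c2)CCN1C(=O)c1cc(OC)c(OC)c(OC)c1` gives 45000 nM. Compound 4 `COc1cc(C(=O)N2CCN(C(=O)c3cc(OC)c(OC)c(OC)c3)C(COC(=O)NC(C)C(C)(C)C)C2)cc(OC)c1OC` differs from compound 1 by (1,2,2-trimethylpropyl)amino in place of nonyl on a carbonyl carbon. Among the measured compounds shown here, the only measured step that touches this side chain is a 16-fold higher number from compound 1 to compound 2 (1.20 log units; beyond the scatter), where a longer chain raised the number sharply. For the measured compounds named here, compound 4 carries a shorter, branched group instead of nonyl, so no step shows what that does; the chain lengthening of compound 2 argues against a worsening, while compound 3, lacking the side chain, shows that losing it does not help. For compound 4 the expected step is a 1.4-fold lower number from compound 1 to compound 4 (0.15 log units; within the scatter), giving an estimated 2000 nM with a range of 500 nM to 8000 nM.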

Compound 4, half-maximal inhibitory concentration: 170 nM
Beside the measured number, compound 4's estimate is 12-fold (1.07 log units) above it, and the stated range ends above it.
By their numbers in this assay, from the lowest: compound 4; then compound 1; then compound 3; then compound 2.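

In this assay, (1,2,2-trimethylpropyl)amino in place of nonyl on this carbonyl carbon gives a 17-fold lower number from compound 1 to compound 4 (1.22 log units; beyond the scatter) and places compound 4 lowest of the four compounds. Among the compounds shown here, the position can therefore move the number down as well as up, whereas the only earlier step here, a 16-fold higher number from compound 1 to compound 2 (1.20 log units; beyond the scatter), went upward with added chain length. Nothing available explains the drop.

The change swaps the carbon group and introduces the nitrogen with its hydrogen together, so their shares remain unseparated. On these data alone, a straight-chain hexylamino group and 1,2,2-trimethylpropyl bonded directly to the carbonyl carbon remain open tests.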